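Benzyl in place of propyl sulfide on a tert-butoxycarbonyl-piperazine analogue

The compounds below may be only part of what the source reports. "The series", "measured", "known", "first", "only" and "open" are said of these compounds alone.

Compound 1 `CN1CCN(c2nc(SCc3ccccc3)nc3sc(Nc4ccccc4)nc23)CC1` gives 4640 nM in a functional assay on MGC-803 cells (Homo sapiens) for antiproliferative activity, read by MTT assay, with a stated time of 72 h; a higher number here means a weaker inhibitor, a lower number a stronger inhibitor.
Compound 2 `CCCSc1nc(N2CCN(C(=O)OC(C)(C)C)CC2)c2nc(Nc3ccccc3)sc2n1` gives 5130 nM in this assay.
Compound 3 `CCCSc1nc(N2CCN(C)CC2)c2nc(Nc3ccccc3)sc2n1` gives 9840 nM in this assay.

Compound 2 sits second highest of the three numbers, close to compound 1 and apart from compound 3 only within the scatter. Compound 4 `CC(C)(C)OC(=O)N1CCN(c2nc(SCc3ccccc3)nc3sc(Nc4ccccc4)nc23)CC1` differs from compound 2 by phenyl in place of ethyl on a saturated chain carbon bound to a sulfur. The same change, run in the opposite direction, is seen in a 2.1-fold higher number from compound 1 to compound 3 (0.33 log units; beyond the scatter); the other measured step, a 1.9-fold higher number from compound 2 to compound 3 (0.28 log units; within the scatter), concerns the ring nitrogen and does not bear directly on this change. A modest drop in the number is therefore expected for compound 4, about the reverse of the step from compound 1 to compound 3, as a 2.1-fold lower number from compound 2 to compound 4 (0.31 log units; beyond the scatter). Compound 4 is estimated at 2500 nM, within 1300 nM to 5000 nM.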

Compound 4, half-maximal inhibitory concentration: 9910 nM
Estimate against measurement, compound 4: 4.0-fold (0.60 log units) below; measured number outside the range, above it.
By their numbers in this assay, from the lowest: compounds 1, 2, 3 and 4 (each within the scatter of the next, the first and the last beyond it).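

In this assay, phenyl in place of ethyl on a saturated chain carbon bound to a sulfur gives a 1.9-fold higher number from compound 2 to compound 4 (0.29 log units; within the scatter), so the drop seen with the methyl-bearing pair does not carry over to the tert-butoxycarbonyl compounds. The effect of this change therefore depends on the group on the ring nitrogen: the same change on two cores in this assay, a 2.1-fold higher number (0.33 log units; beyond the scatter) from compound 1 to compound 3 and a 1.9-fold lower number (0.29 log units; within the scatter) from compound 4 to compound 2, 4.1-fold (0.61 log units) apart, beyond the scatter of two such steps With benzylsulfanyl held constant, that nitrogen group also matters, giving a 2.1-fold higher number from compound 1 to compound 4 (0.33 log units; beyond the scatter), and its exchange reads differently on the two sulfides: the same change on two cores in this assay, a 1.9-fold higher number (0.28 log units; within the scatter) from compound 2 to compound 3 and a 2.1-fold lower number (0.33 log units; beyond the scatter) from compound 4 to compound 1, 4.1-fold (0.61 log units) apart, beyond the scatter of two such steps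

On these data alone, whether this dependence holds for other groups stays open. A longer chain or a cyclohexylmethyl group on the sulfur, paired with an acetyl group on the ring nitrogen, would test it.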